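Sulfonyl substituent and rat microsomal stability

The source may hold more compounds than are shown below. What is called first, only, known or untested is meant among the compounds shown, and "the series" means these compounds.

Going by the values given here, in an ADME assay on microsomes from liver (Rattus norvegicus) for metabolic stability, with a stated time of 10 min (a lower number here means that less of the compound is left, a higher number that more of the compound is left), compound 3 `O=C(NS(=O)(=O)c1ccccc1)c1ccc(Nc2nc(NC3(c4ccc(Cl)cc4)CC3)nc(OCC(F)(F)F)n2)cc1` gives 100%, and no measured compound gives more; compound 1 `CC(C)S(=O)(=O)NC(=O)c1ccc(Nc2nc(NC3(c4ccc(Cl)cc4)CC3)nc(OCC(F)(F)F)n2)cc1` gives 96%, a gap within the scatter, while compound 2 `CC(C)C(=O)NCCS(=O)(=O)NC(=O)c1ccc(Nc2nc(NC3(c4ccc(Cl)cc4)CC3)nc(OCC(F)(F)F)n2)cc1` gives 84%, with a number 16 percentage points higher from compound 2 to compound 3 (beyond the scatter) beyond it. Compound 4 `CC(C)(C)CNCCS(=O)(=O)NC(=O)c1ccc(Nc2nc(NC3(c4ccc(Cl)cc4)CC3)nc(OCC(F)(F)F)n2)cc1` carries the change (2-(neopentylamino)ethyl in place of phenyl on a sulfonyl sulfur). The step of a number 16 percentage points higher from compound 2 to compound 3 (beyond the scatter) bears on it most closely, an open chain exchanged for phenyl on the same sulfonyl sulfur; the step of a number 12 percentage points lower from compound 1 to compound 2 (beyond the scatter) points the same way, whereas a number 4 percentage points higher from compound 1 to compound 3 (within the scatter) stayed within the scatter. Read backwards, these suggest that replacing phenyl with the new chain costs a modest amount, so a number 15 percentage points lower from compound 3 to compound 4 (beyond the scatter) is expected. Compound 4 is thus estimated at 85%, in the range 70% to 98%.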

Compound 4, percent of the compound remaining: 90%
Estimate against measurement, compound 4: 5 percentage points below; measured number inside the range.
By their numbers in this assay, from the lowest: compounds 2, 4, 1 and 3 (each within the scatter of the next, the first and the last beyond it).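

In this assay, the open 2-(neopentylamino)ethyl chain on the sulfonyl sulfur cannot be told apart from phenyl (a number 10 percentage points lower from compound 3 to compound 4 (within the scatter)) or from isopropyl (a number 6 percentage points lower from compound 1 to compound 4 (within the scatter)), so an open chain at this position does not by itself separate from those groups. Neopentyl in place of isopropylcarbonyl on the amine nitrogen also stays within the scatter (a number 6 percentage points higher from compound 2 to compound 4 (within the scatter)), leaving compound 4 unresolved from all three earlier compounds. No measurement shown accounts for these readings. As far as these compounds go, whether a longer chain or a carboxylic acid on the sulfonyl sulfur behaves the same remains open.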